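The source may report more compounds than this note shows. Statements on the series, on what has been measured and on what is new or still open speak of the compounds shown alone.

Of the compounds shown here, two built on a shared core have been tested in an assay on CHO cells with Alpha-2B adrenergic receptor (Homo sapiens) as the target; a lower number here means a smaller maximal response, a higher number a larger maximal response. Compound 1 `CC(C)Oc1ccccc1OC(C)C1=NCCN1` gives 0.5. Compound 2 `CC(=O)c1ccccc1OC(C)C1=NCCN1` gives 0.6; of the two numbers shown its is the larger, but the step a number 0.10 higher from compound 1 to compound 2 (within the scatter) lies within the scatter, so the two compounds cannot be told apart on this evidence. Compound 3 `CCc1ccccc1OC(C)C1=NCCN1` has not yet been measured. It differs from compound 2 in one place: ethyl in place of acetyl on an aromatic carbon. Going by the values given here, the only measured step that bears on this change is the one from compound 1 to compound 2, where acetyl replaced isopropoxy on an aromatic carbon, and that exchange stayed within the scatter. A further exchange of the group on an aromatic carbon is therefore expected to shift the number by no more than the scatter, a number 0.050 lower from compound 2 to compound 3 (within the scatter). Compound 3 is estimated to give about 0.55, with a range from 0.35 to 0.75.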

Compound 3, intrinsic activity: the largest response reached, as a fraction of the reference agonist's: 0.5
Compound 3: middle estimate off by 0.050, on the high side, within the range that was stated.
By their numbers in this assay, from the lowest: compounds 1, 3 and 2 (each within the scatter of the next).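

The change from acetyl to ethyl removes a hydrogen-bond acceptor and a double bond from this aromatic carbon, yet in this assay the result is a number 0.10 lower from compound 2 to compound 3 (within the scatter). Going by these compounds alone, the comparison with the first compound gives no change at the digits printed from compound 1 to compound 3 (within the scatter), so ethyl cannot be told apart from isopropoxy here either. Across the three groups now tested at this position, the maximal response therefore stays within the scatter, and neither that acceptor nor the carbonyl of acetyl proves necessary for it in this series.

Still open, from the compounds shown here alone, is whether an amine, a carboxylic acid or a longer chain on this same carbon would move the response beyond the scatter. Nothing available explains why these three groups give such similar responses.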